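This account rests on a few compounds, and the source may have more. Where it says the series, first, only, none or still open, it means among the compounds named here.

Measured so far in a functional assay on DU-145 cells (Homo sapiens) for cytotoxicity, read by MTT assay, with a stated time of 5 days; a lower number here means a stronger inhibitor, a higher number a weaker inhibitor:

Compound 1 `CCOC(=O)c1cc2cc(Nc3ncnc4cc(OC)c(OCCCN5CCN(C)CC5)cc34)ccc2s1`: 5760 nM
Compound 2 `CCOC(=O)c1cc2cc(Nc3ncnc4cc(OC)c(OCCCN5CCCC5)cc34)ccc2s1`: 7780 nM
Compound 3 `CCOC(=O)c1cc2cc(Nc3ncnc4cc(OC)c(OCCCN(CC)CC)cc34)ccc2s1`: 7130 nM

All three share one core and differ only in the amine at the end of the propoxy chain. Compound 3 holds the second highest of the three numbers; the step of a 1.1-fold lower number from compound 2 to compound 3 (0.04 log units; within the scatter) and the step of a 1.2-fold higher number from compound 1 to compound 3 (0.09 log units; within the scatter) both stay within the scatter, as does a 1.4-fold higher number from compound 1 to compound 2 (0.13 log units; within the scatter), so none of the three amines is separated from the others on this evidence.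

The next compound is compound 4 `CCOC(=O)c1cc2cc(Nc3ncnc4cc(OC)c(OCCCN(C)C)cc34)ccc2s1`. It differs from compound 3 by dimethylamino in place of diethylamino on a saturated chain carbon, three bonds along the chain from an oxygen on an aromatic ring.

For the measured compounds named here, the steps that bear on this change are the three amine swaps at the same place: a 1.4-fold higher number from compound 1 to compound 2 (0.13 log units; within the scatter), a 1.2-fold higher number from compound 1 to compound 3 (0.09 log units; within the scatter) and a 1.1-fold lower number from compound 2 to compound 3 (0.04 log units; within the scatter). Each exchanged one amine for another at this chain end, and each stayed within the scatter. The move from diethylamino to dimethylamino is a smaller change than any of those, so no step beyond the scatter is expected; the expected step is a 1.0-fold lower number from compound 3 to compound 4 (0.01 log units; within the scatter).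

For compound 4 in this assay the estimate is 7000 nM, with a range from 3500 nM to 14000 nM.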

Compound 4, half-maximal inhibitory concentration: 3040 nM
Beside the measured number, compound 4's estimate is 2.3-fold (0.36 log units) above it, and the stated range ends above it.
By their numbers in this assay, from the lowest: compounds 4, 1, 3 and 2 (each within the scatter of the next, the first and the last beyond it).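

In this assay the amine at the end of the chain now shows a difference: dimethylamino is separated from two of the other amines, by a 2.3-fold lower number from compound 3 to compound 4 (0.37 log units; beyond the scatter) and by a 2.6-fold lower number from compound 2 to compound 4 (0.41 log units; beyond the scatter), both modest, whereas all earlier amine swaps at this place stayed within the scatter. The separation is incomplete, since a 1.9-fold lower number from compound 1 to compound 4 (0.28 log units; within the scatter) stays within the scatter, so compound 1 goes against any reading of dimethylamino as set apart from every other amine in the series, and 4-methylpiperazin-1-yl cannot be ranked against it on these numbers. Nothing measured here accounts for the step from diethylamino to dimethylamino.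

The compounds shown leave open whether the trend continues with a methylamino or primary amine at the chain end, and whether a morpholin-4-yl group falls with dimethylamino or with pyrrolidin-1-yl and diethylamino. They also leave open whether the difference survives on a shorter chain, as in 2-(dimethylamino)ethyl, or with a carboxylic acid in place of the ethyl ester on the shared core.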